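Amino for hydroxy, repeated on a second core

The source may hold more compounds than are shown below. What is called first, only, known or untested is meant among the compounds shown, and "the series" means these compounds.

Compound 1 `COc1cccc(/C=C/c2ccccc2O)c1` and compound 2 `COc1ccc(/C=C/c2ccccc2O)cc1` are built from the same atoms joined differently; the difference between the two cores is not broken down here. In a functional assay on MCF7 cells (Homo sapiens) for inhibition, read by MTT assay, with a stated time of 2 days (a higher number here means a weaker inhibitor, a lower number a stronger inhibitor), compound 1 gives 18 ug/mL, and compound 2 gives 17 ug/mL; the two values lie within the scatter of each other. Compound 3 `COc1cccc(/C=C/c2ccccc2N)c1` carries amino in place of hydroxy on an aromatic carbon. In this assay compound 3 gives 6.1 ug/mL, a step of a 3.0-fold lower number from compound 1 to compound 3 (0.47 log units; beyond the scatter). Compound 4 `COc1ccc(/C=C/c2ccccc2N)cc1` is not yet measured; it carries amino in place of hydroxy on an aromatic carbon, the same change at a place described in the same words. The expectation for compound 4 rests on compound 3, because the step of a 3.0-fold lower number from compound 1 to compound 3 (0.47 log units; beyond the scatter) came from exactly this change. Compound 4 is therefore expected to show a step of a 3.0-fold lower number from compound 2 to compound 4 (0.47 log units; beyond the scatter). Compound 4 is estimated at 5.7 ug/mL in this assay.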

Compound 4, half-maximal inhibitory concentration: 0.4 ug/mL
For compound 4 the middle estimate is 14-fold (1.15 log units) above the measured one; measured number outside the range, below it.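

On the core of compound 2, amino in place of hydroxy on an aromatic carbon gives, in this assay, a step of a 43-fold lower number from compound 2 to compound 4 (1.63 log units; beyond the scatter). The direction of the change carries over between the two cores, but its size does not: the same change on two cores in this assay, a 3.0-fold lower number (0.47 log units; beyond the scatter) from compound 1 to compound 3 and a 43-fold lower number (1.63 log units; beyond the scatter) from compound 2 to compound 4, 14-fold (1.16 log units) apart, beyond the scatter of two such steps. A step measured on one core therefore gives the direction on the other in this pair of cores but not a reliable size, and these compounds do not show what in the cores sets the gap.

From the compounds shown here alone, it remains open whether a methylamino or an acetamido group at the same place would follow amino on either core. Also open, going by these compounds, is whether ethoxy in place of methoxy would alter the gap between the two steps.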